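The source may report more compounds than this note shows. Statements on the series, on what has been measured and on what is new or still open speak of the compounds shown alone.

Of the compounds shown here, three sharing one core have been measured in a physicochemical assay for lipophilicity, measured as octanol-water partition; on this read-out higher numbers stand for higher lipophilicity and lower numbers for lower lipophilicity. Compound 1 `COC(=O)c1cn(C/C=C(/C)CC/C=C(\C)CCC=C(C)C)nn1` gives 5.25, compound 2 `CC(C)=CCC/C(C)=C/CC/C(C)=C\Cn1cc(-c2ccccc2)nn1` gives 6.95, and compound 3 `CCCCCCCCc1cn(C/C=C(/C)CC/C=C(\C)CCC=C(C)C)nn1` gives 8.76. Compound 2 thus stands second highest of the three, with compound 1 lower and compound 3 higher. Compound 4 `CC(C)=CCC/C(C)=C\Cn1cc(-c2ccccc2)nn1` differs from compound 2 in the chain: hydrogen in place of 3-methylbut-2-en-1-yl on a saturated chain carbon bound to a double-bonded chain carbon. In words, hydrogen stands in place of 3-methylbut-2-en-1-yl. Among the measured compounds shown here, no measured step changes this chain, since all three concern the group on an aromatic carbon. These are a number 1.70 log units higher from compound 1 to compound 2 (beyond the scatter), a number 1.81 log units higher from compound 2 to compound 3 (beyond the scatter) and a number 3.51 log units higher from compound 1 to compound 3 (beyond the scatter), each large and beyond the scatter. The nearest guide is the octyl in place of phenyl swap, a number 1.81 log units higher from compound 2 to compound 3 (beyond the scatter), where a larger all-carbon chain goes with a higher number. Here an all-carbon group leaves, so a large step downward is expected in this assay, similar in size to that swap. The estimated change is a number 1.65 log units lower from compound 2 to compound 4 (beyond the scatter). Compound 4 is expected at 5.3, within an estimated range of 4.7 to 5.9.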

Compound 4, partition coefficient: 4.91
Beside the measured number, compound 4's estimate is 0.39 log units above it, within the range that was stated.
By their numbers in this assay, from the lowest: compound 4; then compound 1; then compound 2; then compound 3.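

Hydrogen in place of 3-methylbut-2-en-1-yl, on a saturated chain carbon bound to a double-bonded chain carbon, gives in this assay a step of a number 2.04 log units lower from compound 2 to compound 4 (beyond the scatter) and this is the first step read at the chain rather than at the group on an aromatic carbon. It shows that this place also carries a large change in the read-out, here on the loss of 5 heavy atoms, all carbon, with 1 double bond outside aromatic rings. Nothing at hand explains the size of this step.

As far as these compounds go, whether the step would keep its size with octyl or methoxycarbonyl on the aromatic carbon stays open, as only the phenyl compounds show it. Also open, from the compounds shown here alone, is how the number would respond at this chain carbon to a shorter chain, a longer chain, a hydroxyl group or an amine.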